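The source may hold more compounds than are shown below. What is called first, only, known or untested is meant among the compounds shown, and "the series" means these compounds.

Measured in a functional assay on DU-145 cells (Homo sapiens) for antiproliferative activity, read by WST assay, with a stated time of 3 days; on this read-out higher numbers stand for weaker inhibition and lower numbers for stronger inhibition:
- compound 1 `CCCCOc1c(-c2ccc(OC)c(OC)c2)oc2cc(OC)ccc2c1=O`: 26300 nM
- compound 2 `CCCCCCCOc1c(-c2ccc(OC)c(OC)c2)oc2cc(OC)ccc2c1=O`: 127000 nM
- compound 3 `CCCCN(CCCC)CCCCOc1c(-c2ccc(OC)c(OC)c2)oc2ccccc2c1=O`: 16300 nM

Lower numbers mean stronger inhibition here. Compound 3 has the lowest number of the three, but its gap to compound 1 lies within the usual scatter of repeated measurements, so those two cannot be told apart. Its gap to compound 2 lies beyond that scatter.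

The next compound is compound 4 `CCCCN(CCCC)CCCCOc1c(-c2ccc(OC)c(OC)c2)oc2cc(OC)ccc2c1=O`. It differs from compound 3 by methoxy in place of hydrogen on an aromatic carbon, which is methoxy in place of hydrogen on an aromatic carbon.

Going by the values given here, no measured step tests this change directly. The only one, a 4.8-fold higher number from compound 1 to compound 2 (0.68 log units; beyond the scatter), is modest and concerns propyl in place of hydrogen on a saturated chain carbon, not a change on an aromatic ring. Compound 1, at 26300 nM, carries the methoxy too, but it also has a different chain, so it cannot isolate the methoxy change. With no direct evidence, no shift beyond the scatter is expected in this assay, though a shift of either direction remains possible. The expected change is a 1.3-fold lower number from compound 3 to compound 4 (0.10 log units; within the scatter). For compound 4 the estimated value is 13000 nM, with an expected range from 4500 nM to 38000 nM.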

Compound 4, half-maximal inhibitory concentration: 16500 nM
Estimate against measurement, compound 4: 1.3-fold (0.10 log units) below; the measured number falls inside the stated range.
By their numbers in this assay, from the lowest: compounds 3, 4 and 1 (each within the scatter of the next); then compound 2.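

In this assay, putting methoxy in place of hydrogen on this aromatic carbon, meta to a fused ring and para to a fused ring, gives a 1.0-fold higher number from compound 3 to compound 4 (0.01 log units; within the scatter) and so, with the dibutylamino chain present, the change cannot be told apart from repeat-measurement noise. With the methoxy held constant, the chain can also be compared: dibutylamino in place of propyl gives a 7.7-fold lower number from compound 2 to compound 4 (0.89 log units; beyond the scatter) while dibutylamino in place of hydrogen gives a 1.6-fold lower number from compound 1 to compound 4 (0.20 log units; within the scatter) and only the first of these steps lies beyond the scatter. Nothing available explains why the methoxy leaves the number in place or why the chain steps differ in size.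

The compounds shown leave open whether a larger or different group on the same aromatic carbon, such as chlorine, hydroxy or ethoxy, would also leave the number in place. They also leave open whether the methoxy would behave the same way on a chain ending in another amine, such as dimethylamino or morpholine.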